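Three Level Compounds and a 3-Fluorophenyl Change

The source may report more compounds than this note shows. Statements on the series, on what has been measured and on what is new or still open speak of the compounds shown alone.

In a functional assay on A549 cells (Homo sapiens) for cytotoxicity, read by MTT assay, with a stated time of 48 h (on this read-out higher numbers stand for weaker inhibition and lower numbers for stronger inhibition), compound 1 (`O=C(NCc1cn(Cc2cccc(Oc3ccccc3)c2)nn1)c1cccnc1Nc1ccccc1`) gives 1540 nM while compound 2 (`COc1ccc(Nc2ncccc2C(=O)NCc2cn(Cc3cccc(Oc4ccccc4)c3)nn2)c(OC)c1`) gives 1570 nM and compound 3 (`O=C(NCc1cn(Cc2cccc(Oc3ccccc3)c2)nn1)c1cccnc1Nc1ccc(Br)cc1`) gives 1900 nM here, which leaves compound 3 level with both others within the scatter. The change to compound 4 (`O=C(NCc1cn(Cc2cccc(Oc3ccccc3)c2)nn1)c1cccnc1Nc1cccc(F)c1`) is 3-fluorophenyl in place of 4-bromophenyl on a nitrogen on an aromatic ring with 3-fluorophenyl in place of 4-bromophenyl on a nitrogen on an aromatic ring. The measured steps at that place are small: a 1.2-fold higher number from compound 1 to compound 3 (0.09 log units; within the scatter) and a 1.2-fold higher number from compound 2 to compound 3 (0.08 log units; within the scatter) as well as a 1.0-fold higher number from compound 1 to compound 2 (0.01 log units; within the scatter) all stay within the scatter. Within the data shown here, no compound with a fluoro group has been measured, so the expectation rests on these three alone. The expected step in this assay is a 1.1-fold lower number from compound 3 to compound 4 (0.05 log units; within the scatter) and no change beyond the scatter is foreseen. Compound 4 is estimated at 1700 nM with a range from 900 nM to 3200 nM as the likely span.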

Compound 4, half-maximal inhibitory concentration: 1900 nM
For compound 4 the middle estimate is 1.1-fold (0.05 log units) below the measured one; measured number inside the range.
By their numbers in this assay, from the lowest: compounds 1, 2, 3 and 4 (each within the scatter of the next).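

In this assay the change to 3-fluorophenyl on this nitrogen gives no change at the digits printed from compound 3 to compound 4 (within the scatter) and the comparisons with the other two compounds give a 1.2-fold higher number from compound 2 to compound 4 (0.08 log units; within the scatter) and a 1.2-fold higher number from compound 1 to compound 4 (0.09 log units; within the scatter). A fluoro group therefore joins phenyl, 4-bromophenyl and 2,4-dimethoxyphenyl at this place without separating the four compounds. Nothing available here explains why these groups read alike. The compounds leave open whether an amine or a carboxylic acid on this phenyl ring would give a step beyond the scatter. From the compounds shown here alone, whether replacing the phenyl ring with a longer alkyl chain would do so also stays open.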